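Chloro to Iodo Swap Across Two Related Cores

The source may report more compounds than this note shows. Statements on the series, on what has been measured and on what is new or still open speak of the compounds shown alone.

Measured compounds:
Compound 1 `N=C(N)c1ccc(COc2ccc(C(=N)N)cc2Cl)cc1`: 3200000 nM
Compound 2 `N=C(N)c1ccc(COc2ccc(C(=N)N)cc2I)cc1`: 5300000 nM
Compound 3 `N=C(N)c1cccc(COc2ccc(C(=N)N)cc2Cl)c1`: 13900000 nM

Compounds 1 and 2 share a core and differ only by iodo in place of chloro on an aromatic carbon. In an ADME assay on L6 cells (Rattus norvegicus) for cytotoxicity, read by resazurin assay, with a stated time of 72 h (on this read-out lower numbers stand for stronger inhibition and higher numbers for weaker inhibition), compound 1 gives 3200000 nM and compound 2 gives 5300000 nM; the step of a 1.7-fold higher number from compound 1 to compound 2 (0.22 log units; within the scatter). Compound 3 is built from the same atoms as compound 1, joined differently; the difference between the two cores is not broken down here. Compound 3 shows the highest number of the three measured.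

Compound 4 `N=C(N)c1cccc(COc2ccc(C(=N)N)cc2I)c1` is not yet measured. It differs from compound 3 by iodo in place of chloro on an aromatic carbon, the same change as from compound 1 to compound 2, at a place described in identical terms. Because the earlier step of a 1.7-fold higher number from compound 1 to compound 2 (0.22 log units; within the scatter) stayed within the scatter, the step from compound 3 to compound 4 is expected to be similarly modest, a 1.7-fold higher number from compound 3 to compound 4 (0.22 log units; within the scatter). Compound 4 is therefore estimated at 23000000 nM in this assay, with a likely range from 10000000 nM to 50000000 nM.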

Compound 4, half-maximal inhibitory concentration: 6060000 nM
Estimate against measurement, compound 4: 3.8-fold (0.58 log units) above, outside the stated range (below it).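

In this assay, iodo in place of chloro gives a 2.3-fold lower number from compound 3 to compound 4 (0.36 log units; beyond the scatter). Set beside the earlier step, this shows that the change does not carry over unchanged from one core to the other in this series, and that what it does here depends on the core: the same change on two cores in this assay, a 1.7-fold higher number (0.22 log units; within the scatter) from compound 1 to compound 2 and a 2.3-fold lower number (0.36 log units; beyond the scatter) from compound 3 to compound 4, 3.8-fold (0.58 log units) apart, beyond the scatter of two such steps

This comparison rests on just two pairs of compounds, and it does not show which difference between the two cores matters or how the change would behave on any further core. The compounds shown leave open how a bromo, fluoro or methoxy group on that aromatic carbon would behave on either core. As far as these compounds go, whether such groups would also differ between the two cores remains open as well.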